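From cyclopropyl to 4-methylphenyl on the nitrogen

This account rests on a few compounds, and the source may have more. Where it says the series, first, only, none or still open, it means among the compounds named here.

In a functional assay on KBVIN cells (Homo sapiens) for cytotoxicity, read by MTT assay, with a stated time of 72 h (on this read-out lower numbers stand for an effect already at smaller amounts and higher numbers for an effect only at larger amounts of compound), compound 1 `O=c1cc(NC2CC2)cc(-c2ccccc2)o1` gives > 30 uM, which is a limit of the assay and not a number.

Compound 4 `Cc1ccc(Nc2cc(-c3ccccc3)oc(=O)c2)cc1` keeps the core of compound 1 and changes one group: 4-methylphenyl in place of cyclopropyl on a nitrogen on an aromatic ring. For the measured compounds named here, no measured step changes the group at this place. Going by the values given here, the one measured step, a 48-fold lower number from compound 2 to compound 3 (1.68 log units; beyond the scatter), lies on an aromatic carbon instead, so it bears on this change only indirectly. It does show how widely the numbers can spread among compounds with a six-membered aromatic ring on that nitrogen: compound 2 `CCCCCc1cc(Nc2ccc(OC)cc2)cc(=O)o1` gives 4.84 uM, and compound 3 `COc1ccc(Nc2cc(/C=C/c3ccccc3)oc(=O)c2)cc1` gives 0.1 uM.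

Compound 4 also has such a ring on the nitrogen but lacks the 2-phenylethenyl group of compound 3, so its number is expected to lie nearer that of compound 2, at 4.84 uM. A step to a lower number, beyond the scatter, is therefore expected, estimated as an at least 15-fold lower number from compound 1 to compound 4 (1.17 log units; beyond the scatter). For compound 4 the expected value is 2 uM, with an estimated range from 0.3 uM to 15 uM.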

Compound 4, concentration for half-maximal effect: 0.059 uM
Compound 4: the middle estimate sits 34-fold (1.53 log units) above what was measured, and the stated range ends above it.
By their numbers in this assay, from the lowest: compounds 4 and 3 (each within the scatter of the next); then compound 2. At a limit, above all of these: compound 1.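

For the compounds shown here, until now, no measured step had touched the group on this nitrogen. Here that group alone changes, and this assay gives an at least 500-fold lower number from compound 1 to compound 4 (2.70 log units; beyond the scatter), so this place has a large effect on the read-out even in a compound without the 2-phenylethenyl group. The true size of the step stays unknown, because compound 1 stands at a limit and not at a number: the limit of > 30 uM in this assay, at which 1 of the 4 values shown sits.

The compounds shown leave open whether the step comes from the aromatic ring itself or from its methyl group, and a plain phenyl on this nitrogen would separate the two. Also open, going by these compounds, is how a cyclohexyl group in place of the 4-methylphenyl would read, which would test a larger ring that is not aromatic.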